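What Happens When the Butyl Group Is Removed

This account rests on a few compounds, and the source may have more. Where it says the series, first, only, none or still open, it means among the compounds named here.

Compound 1 `CCCCc1cn(C[C@H](O)[C@H]2OC(=O)C(OCc3ccccc3)=C2OCc2ccccc2)nn1`: in a functional assay on HepG2 cells (Homo sapiens) for antiproliferative activity, read by MTT assay, with a stated time of 72 h (on this read-out lower numbers stand for stronger inhibition and higher numbers for weaker inhibition), compound 1 gives 32800 nM.
Compound 2 `COc1ccccc1-c1cn(C[C@H](O)[C@H]2OC(=O)C(OCc3ccccc3)=C2OCc2ccccc2)nn1`: compound 2 reaches only the limit of > 100000 nM.
Compound 3 `COc1ccccc1-c1cn(C/C=C2\OC(=O)C(OCc3ccccc3)=C2OCc2ccccc2)nn1`: compound 3 likewise reaches only the limit of > 100000 nM.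

Within the data shown here, compound 1 holds the only number in this set; the other two values are limits of the assay, as the limit of > 100000 nM in this assay, at which 2 of the 3 values shown sit, shows. Among the measured compounds shown here, the one comparable step runs an at least 3.0-fold higher number from compound 1 to compound 2 (0.48 log units; beyond the scatter), so the sole change measured on the triazole carbon pushed the value out of range.

Compound 4 `O=C1O[C@H]([C@@H](O)Cn2ccnn2)C(OCc2ccccc2)=C1OCc1ccccc1` differs from compound 1 by hydrogen in place of butyl on an aromatic carbon. For the measured compounds named here, no measured step removes a group at that carbon, so the direction rests only on the fact that compound 1 is already weak and that the one change made there did not help. Compound 4 is therefore expected to sit no stronger than compound 1, most likely weaker, with the step estimated as a 1.8-fold higher number from compound 1 to compound 4 (0.26 log units; within the scatter). Compound 4 is expected to give about 60000 nM, within 25000 nM to 150000 nM.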

Compound 4, half-maximal inhibitory concentration: > 100000 nM
Compound 4: no number, only a limit (the forecaster's own chance of this, stated with the estimate: 40%); middle value at least 1.6-fold (0.22 log units) from the limit.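

Taking the butyl group off the triazole carbon and leaving hydrogen there does not keep the value of compound 1, and the step runs an at least 3.0-fold higher number from compound 1 to compound 4 (0.48 log units; beyond the scatter). The earlier compounds showed only that 2-methoxyphenyl at this carbon gave no number; compound 4 shows the same for hydrogen, so of the three substituents shown at this carbon, only butyl gives a readable value, and that value is itself weak: the limit of > 100000 nM in this assay, at which 3 of the 4 values shown sit. The step from compound 2 to compound 4 cannot be read, as both values are limits.

Going by these compounds, how compound 4 truly stands remains open, since its value is only a limit. Also open, on these data alone, is whether a longer chain such as hexyl, or an amine at the end of the butyl chain, would give a lower number than compound 1.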